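Ring contraction of the basic amine in the series

The compounds below may be only part of what the source reports. "The series", "measured", "known", "first", "only" and "open" are said of these compounds alone.

For the measured compounds named here, compound 2 `Nc1nc(C(F)(F)F)cc2c1[nH]c(=O)n2Cc1ccc(NCCN2CCCCC2)nc1` is the only member of the series with a number rather than a limit in an in vitro ADME assay on microsomes from liver (Rattus norvegicus) for pharmacokinetics; a higher number here means faster removal of the compound, a lower number slower removal: in this assay compound 2 gives 16 mL.min-1.g-1. Compound 1 `CN(C)CCN1CCN(c2ccc(Cn3c(=O)[nH]c4c(N)nc(C(F)(F)F)cc43)cn2)CC1` is the compound standing at the limit of < 8.5 mL.min-1.g-1 in this assay, at which 1 of the 2 values shown sits; in this assay compound 1 gives < 8.5 mL.min-1.g-1, a limit of the assay rather than a number. Going by the values given here, the one measured step, an at least 1.8-fold higher number from compound 1 to compound 2 (0.27 log units; that floor lies within the scatter), concerns a different replacement of the whole amine side chain and rests on a floor, so it informs the new step only weakly. Compound 3 `Nc1nc(C(F)(F)F)cc2c1[nH]c(=O)n2Cc1ccc(NCCN2CCCC2)nc1` carries pyrrolidin-1-yl in place of piperidin-1-yl on a saturated chain carbon, two bonds along the chain from a nitrogen on an aromatic ring. Among the compounds with values here, no measured step isolates this change, so no movement beyond the scatter is expected in this assay. For compound 3 the expected step is no change at the digits printed from compound 2 to compound 3 (within the scatter). Compound 3 is accordingly estimated at 16 mL.min-1.g-1, with a range from 8 mL.min-1.g-1 to 32 mL.min-1.g-1 in this assay.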

Compound 3, intrinsic clearance in microsomes: < 8.5 mL.min-1.g-1
Compound 3: no number, only a limit (the forecaster's own chance of this, stated with the estimate: 20%); at least 1.8-fold (0.27 log units) between middle value and limit.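

Working notes: pyrrolidin-1-yl in place of piperidin-1-yl, on a saturated chain carbon, two bonds along the chain from a nitrogen on an aromatic ring, gives in this assay an at least 1.8-fold lower number from compound 2 to compound 3 (0.27 log units; that floor lies within the scatter). For the compounds shown here, this is the first step that isolates the ring on this chain, but compound 3 gives a limit of the assay rather than a number, so the step is only a floor and does not pass the scatter. The step from compound 1 to compound 3 cannot be read, and compound 2 remains the only number in the series: the limit of < 8.5 mL.min-1.g-1 in this assay, at which 2 of the 3 values shown sit.

The compounds shown leave open how large the step really is, and whether it extends to other rings on this chain, such as azetidin-1-yl or morpholin-4-yl. They also leave open whether the same ring change reads alike on a longer chain.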